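Furan-2-yl in place of naphthalen-1-yl on compound 1

A few compounds are considered here, and "the series" means these few. Any claim that something is new, unique, unknown or untested is made for them only; others in the source may bear on it.

In a functional assay on HCT-116 cells (Homo sapiens) for inhibition, read by sulforhodamine B assay, with a stated time of 48 h, tested at 50 uM (on this read-out lower numbers stand for less inhibition of growth and higher numbers for more inhibition of growth at the one concentration tested), compound 1 (`COc1cc(/C=C/C(=O)/C=C/c2cccc3ccccc23)ccc1OCc1cn(CCCCCOc2cc(=O)oc3ccccc23)nn1`) gives 42%. This is the lower of the two numbers available, since compound 2 (`COc1cc(/C=C/C(=O)/C=C/c2ccccc2)ccc1OCc1cn(CCOc2cc(=O)oc3ccccc23)nn1`) gives 56%, a gap beyond the usual scatter. Compound 2 differs from compound 1 in more than one place, so the gap cannot be tied to any single change. Compound 3 (`COc1cc(/C=C/C(=O)/C=C/c2ccco2)ccc1OCc1cn(CCCCCOc2cc(=O)oc3ccccc23)nn1`) keeps the rest of compound 1 but carries furan-2-yl in place of naphthalen-1-yl on a double-bonded chain carbon bound to a double-bonded chain carbon. For the measured compounds named here, no measured pair isolates this change. Going by the values given here, the only guide is the higher number of compound 2 at 56%, so a small rise in this assay, of about the size of the scatter, is expected. The expected change is a number 6 percentage points higher from compound 1 to compound 3 (within the scatter). The estimated value for compound 3 is 48%, with an expected range from 33% to 63%.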

Compound 3, percent growth inhibition at one concentration: 37%
Compound 3: the middle estimate sits 11 percentage points above what was measured; the measured number falls inside the stated range.
By their numbers in this assay, from the lowest: compounds 3 and 1 (each within the scatter of the next); then compound 2.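

For the compounds shown here, the step in this assay is a number 5 percentage points lower from compound 1 to compound 3 (within the scatter), and it is the first comparison in this set that isolates a single change. At this place, on a double-bonded chain carbon bound to a double-bonded chain carbon, the two six-membered aromatic rings of naphthalen-1-yl can give way to the one five-membered aromatic ring of furan-2-yl with no difference beyond the scatter in this read-out. No measurement available here explains this result.

From the compounds shown here alone, whether a group bearing an amine or a carboxylic acid at this place would give a different number remains open. What separates compound 2 from compound 1 and compound 3 also remains unresolved, since compound 2 differs from each of them in more than one place.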